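This account rests on a few compounds, and the source may have more. Where it says the series, first, only, none or still open, it means among the compounds named here.

Measured compounds:
compound 1, `CC(C)N(Cc1cccc(OCCCCCC(=O)O)c1)C(=O)c1ccc(-c2cccc3ccccc23)cc1`, gives in an ADME assay on HepG2 cells (Homo sapiens) for cytotoxicity, read by CellTiter-Glo and resazurin assay, with a stated time of 72 h (on this read-out lower numbers stand for an effect already at smaller amounts and higher numbers for an effect only at larger amounts of compound), a value of > 26000 nM, which is a limit of the assay.
compound 2, `CC(C)COc1cccc(-c2ccc(C(=O)N(Cc3cccc(OCCCCCC(=O)O)c3)C(C)C)cc2)c1`, gives in this assay > 26000 nM, again a limit.
compound 3, `CC(C)N(Cc1cccc(OCCCCCC(=O)O)c1)C(=O)c1ccc(-c2ccsc2)cc1`, gives in this assay > 26000 nM, also a limit.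

Compound 3 therefore stands at no number at all: its result in this assay is a limit, and the same holds for the two other compounds, as the limit of > 26000 nM in this assay, at which 3 of the 3 values shown sit, shows. The piece now turns to compound 4, `CCOc1cccc(-c2ccc(C(=O)N(Cc3cccc(OCCCCCC(=O)O)c3)C(C)C)cc2)c1`, which differs from compound 3 in a single place: 3-ethoxyphenyl in place of thiophen-3-yl on an aromatic carbon, the new group being a six-membered aromatic ring of carbon only that enters on an aromatic carbon para to a large group.

The measured steps that bear on this change are a step that the two limits leave unreadable from compound 1 to compound 3 and a step that the two limits leave unreadable from compound 2 to compound 3, neither of which yields a readable size, since both ends sit at the limit. Compound 2 carries a 3-(isobutoxy)phenyl in the same place and also stays at the limit. For the measured compounds named here, no step in this set shows a readable change in this assay, so for compound 4 no shift beyond the scatter is expected; the estimated step that the limit leaves unreadable from compound 3 to compound 4 is expected to be nil. Compound 4 is expected to give about 40000 nM, within 20000 nM to 100000 nM, most likely again as a limit.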

Compound 4, half-maximal effective concentration: > 20800 nM
Compound 4 gave a limit, no number; the forecaster's own chance of this, stated with the estimate: 85%; the middle value lies beyond the limit too.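

Compound 4 also gives only a limit, so its steps from compound 1, compound 2 and compound 3 in this assay cannot be read: the limit of > 20800 nM in this assay, at which 1 of the 4 values shown sits.

The compounds shown leave open at what concentration any of the four would reach the half-maximal effect, and whether exchanging the group on the aromatic carbon alters that concentration.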